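The source may report more compounds than this note shows. Statements on the series, on what has been measured and on what is new or still open speak of the compounds shown alone.

In a functional assay on A549 cells (Homo sapiens) for antiproliferative activity, read by sulforhodamine B assay, with a stated time of 48 h (a higher number here means a weaker inhibitor, a lower number a stronger inhibitor), compound 1 (`COc1cc(OC)c2sc(-c3ccc(N/C=C\C(=O)c4ccc(OC)c([N+](=O)[O-])c4)c(C)c3)nc2c1`) gives 12100 nM and sits within the scatter of compound 3 (`COc1cc(OC)c2sc(-c3ccc(N/C=C\C(=O)c4cc(OC)c(OC)c([N+](=O)[O-])c4)c(C)c3)nc2c1`) at 15400 nM while compound 2 (`COc1cc(OC)c2sc(-c3ccc(N/C=C\C(=O)c4ccc(OC)c([N+](=O)[O-])c4)cc3)nc2c1`) lies lower at 5800 nM in this small set. Compound 4 (`COc1cc(OC)c2sc(-c3ccc(N/C=C\C(=O)c4ccc(OC)c(F)c4)c(C)c3)nc2c1`) carries fluoro in place of nitro on an aromatic carbon, ortho to a methoxy group (fluoro in place of nitro on an aromatic carbon). Two measured steps start from compound 1, namely a 2.1-fold lower number from compound 1 to compound 2 (0.32 log units; beyond the scatter) for hydrogen in place of methyl and a 1.3-fold higher number from compound 1 to compound 3 (0.10 log units; within the scatter) for methoxy in place of hydrogen. On these data alone, neither step touches the nitro group, so this change is untested and only a small shift is expected. The estimated change is a 1.2-fold lower number from compound 1 to compound 4 (0.08 log units; within the scatter) with no firm direction expected. For compound 4 the expected value is 10000 nM within an estimated range of 3500 nM to 28000 nM for now.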

Compound 4, half-maximal inhibitory concentration: 15300 nM
Estimate against measurement, compound 4: 1.5-fold (0.18 log units) below; the measured number falls inside the stated range.
By their numbers in this assay, from the lowest: compound 2; then compounds 1, 4 and 3 (each within the scatter of the next).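

In this assay, among the compounds shown here, the change from 4-methoxy-3-nitrophenyl to 3-fluoro-4-methoxyphenyl gives a 1.3-fold higher number from compound 1 to compound 4 (0.10 log units; within the scatter) and is the first measured change at this position. With the methyl-bearing core of compound 1, replacing nitro, with its 3 heavy atoms and 2 hydrogen-bond acceptors, by fluoro, with 1 heavy atom and none, leaves the number within the scatter. No evidence is available to explain this result.

On these data alone, whether an amine or a carboxylic acid at this position would shift the number remains open. Also open, as far as these compounds go, is whether fluoro would behave the same way on the core of compound 2.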